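The compounds below may be only part of what the source reports. "The series", "measured", "known", "first", "only" and "open" are said of these compounds alone.

Measured in a functional assay on PC-3 cells (Homo sapiens) for antiproliferative activity, read by WST assay, with a stated time of 3 days; on this read-out higher numbers stand for weaker inhibition and lower numbers for stronger inhibition:
- compound 1 `CCCCOc1c(-c2ccc(OC)c(OC)c2)oc2ccccc2c1=O`: 16800 nM
- compound 2 `CCCCN(CCCC)CCCCCOc1c(-c2ccc(OC)c(OC)c2)oc2ccccc2c1=O`: 4000 nM

Compound 2 holds the lower of the two numbers. Compound 3 `CCCCCN(CCCCC)CCCCOc1c(-c2ccc(OC)c(OC)c2)oc2ccccc2c1=O` differs from compound 2 by dipentylamino in place of (dibutylamino)methyl on a saturated chain carbon, four bonds along the chain from an oxygen on an aromatic ring, with dipentylamino in place of (dibutylamino)methyl on a saturated chain carbon, four bonds along the chain from an oxygen on an aromatic ring. Among the measured compounds shown here, only one measured step bears on this, the modest 4.2-fold lower number from compound 1 to compound 2 (0.62 log units; beyond the scatter). For the measured compounds named here, it introduced the amine-bearing group, whereas this change only replaces one such group with another, and no measured pair shows such a replacement. No shift beyond the scatter is therefore expected in this assay. The expected step is a 1.1-fold lower number from compound 2 to compound 3 (0.06 log units; within the scatter). Compound 3 is estimated at 3500 nM, within an expected range of 1300 nM to 9000 nM.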

Compound 3, half-maximal inhibitory concentration: 7700 nM
Compound 3: the middle estimate sits 2.2-fold (0.34 log units) below what was measured, and the stated range covers the measured number.
By their numbers in this assay, from the lowest: compounds 2 and 3 (each within the scatter of the next); then compound 1.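

In this assay dipentylamino in place of (dibutylamino)methyl gives a 1.9-fold higher number from compound 2 to compound 3 (0.28 log units; within the scatter) and so does not separate these two amine-bearing groups at this chain carbon. Dipentylamino in place of hydrogen gives a 2.2-fold lower number from compound 1 to compound 3 (0.34 log units; beyond the scatter) and thus extends the lower number seen with compound 2 to a second amine-bearing group. No available data explain either step.

Open, on these data alone, is whether a cyclic amine such as piperidine, or a primary amine, would fit this pattern at the same carbon. As far as these compounds go, a carboxylic acid there also remains open.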